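This account rests on a few compounds, and the source may have more. Where it says the series, first, only, none or still open, it means among the compounds named here.

Compound 3 `CCN(CC)c1ccc(OCCCCCOc2cccc(NC(N)=S)c2)cc1` is one of three measured compounds that share one core and differ only in a single group on an aromatic carbon. In an ADME assay on Ava5 cells (Homo sapiens) for cytotoxicity (a higher number here means that more compound is tolerated, a lower number that less compound is tolerated), compound 3 gives > 50000 nM, which is a limit of the assay and not a number. Compound 1 `NC(=S)Nc1cccc(OCCCCCOc2ccccc2)c1` carries hydrogen at that place, and in this assay compound 1 gives > 50000 nM, again a limit rather than a number. Compound 2 `NC(=S)Nc1cccc(OCCCCCOc2ccc(Cl)cc2)c1` carries chloro there, and in this assay compound 2 gives 7000 nM. The step of an at least 7.1-fold lower number from compound 1 to compound 2 (0.85 log units; beyond the scatter) thus lowers the value, and the step of an at least 7.1-fold higher number from compound 2 to compound 3 (0.85 log units; beyond the scatter) raises it back. The step that the two limits leave unreadable from compound 1 to compound 3 cannot be sized because of the limit of > 50000 nM in this assay, at which 2 of the 3 values shown sit.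

Compound 4 `NC(=S)Nc1cccc(OCCCCCOc2ccc(N3CCCCC3)cc2)c1` is not yet measured. It differs from compound 3 by piperidin-1-yl in place of diethylamino on an aromatic carbon. Of the measured steps only an at least 7.1-fold higher number from compound 2 to compound 3 (0.85 log units; beyond the scatter) bears on this change, and it shows an amino group at this place leaving more compound tolerated than chloro does. Whether a second amino group shifts the value further cannot be read, since compound 3 sits at a limit. The step of a number no higher from compound 3 to compound 4 (the limit leaves the size open) is therefore expected to be none beyond the scatter. Compound 4 is expected to give about 50000 nM in this assay, within 15000 nM to 150000 nM, most likely again as a limit.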

Compound 4, half-maximal cytotoxic concentration: 12000 nM
Estimate against measurement, compound 4: 4.2-fold (0.62 log units) above; the whole stated range lies above it.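

In this assay, within the data shown here, the two amino groups turn out not to be interchangeable at this place, para to a large group (the step is an at least 4.1-fold lower number from compound 3 to compound 4 (0.61 log units; beyond the scatter)); the earlier compounds compared diethylamino only with chloro and hydrogen, whereas here the open diethylamino is replaced by piperidin-1-yl, a six-membered non-aromatic ring with one more heavy atom. Having an amino group at this place therefore does not by itself keep the value high, as the comparison with the unsubstituted compound also shows (an at least 4.1-fold lower number from compound 1 to compound 4 (0.61 log units; beyond the scatter)). Piperidin-1-yl and chloro cannot be told apart here (a 1.7-fold higher number from compound 2 to compound 4 (0.23 log units; within the scatter)), so the earlier contrast between amino and chloro holds for diethylamino but not for piperidin-1-yl.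

The compounds shown leave open where other amino groups would fall, such as dimethylamino with its shorter open chains, pyrrolidin-1-yl with its smaller ring, or morpholin-4-yl with an oxygen in the ring. The step between compound 1 and compound 3 cannot be read, and the full size of the steps from these two compounds to compound 4 stays open, because of this limit: the limit of > 50000 nM in this assay, at which 2 of the 4 values shown sit.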